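A few compounds are considered here, and "the series" means these few. Any claim that something is new, unique, unknown or untested is made for them only; others in the source may bear on it.

Compound 2, `COC(=O)c1cccc(NC(=O)C2CCCN(C(=O)c3cc(C(F)(F)F)cc(C(F)(F)F)c3)C2)c1`, and compound 1, `O=C(Nc1cccc(OCCc2ccccn2)c1)C1CCCN(C(=O)c2cc(C(F)(F)F)cc(C(F)(F)F)c2)C1`, share the same core and differ only in the group on the aromatic carbon of the aniline ring. In an ADME assay on PC-3 cells (Homo sapiens) for cytotoxicity, read by WST assay, tested at 100 uM (on this read-out lower numbers stand for less inhibition and higher numbers for more inhibition at the one concentration tested (going by the name of the read-out)), compound 1 gives 5%, and compound 2 gives 0%. Going by the values given here, compound 2 thus stands at the lower of the two numbers seen, with compound 1 as its only neighbour, a step of a number 5 percentage points lower from compound 1 to compound 2 (within the scatter) separating them.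

Compound 3, `CC(=O)c1cccc(NC(=O)C2CCCN(C(=O)c3cc(C(F)(F)F)cc(C(F)(F)F)c3)C2)c1`, is reached from compound 2 by a single change: methyl in place of methoxy on a carbonyl carbon. Among the compounds with values here, no measured pair shows this exact change. Within the data shown here, the only step available, a number 5 percentage points lower from compound 1 to compound 2 (within the scatter), touches a different part of the molecule and tells mainly that swapping the group on the aniline ring has left the read-out near zero. With both measured numbers flat and the change in compound 3 small, the expected step of a number 2 percentage points higher from compound 2 to compound 3 (within the scatter) in this assay is none beyond the scatter. Compound 3 is therefore estimated at 2%, within a range from -8% to 12%.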

Compound 3, a percentage reported as inhibition, at one concentration (the size of the read-out at that concentration, not a potency): 0%
Compound 3: middle estimate off by 2 percentage points, on the high side; the range from low to high includes it.
By their numbers in this assay, from the lowest: compounds 2, 3 and 1 (each within the scatter of the next).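

In this assay, going by these compounds alone, methyl in place of methoxy on a carbonyl carbon, which turns methoxycarbonyl into acetyl, gives no change at the digits printed from compound 2 to compound 3 (within the scatter); this is the first look at a change on that carbonyl carbon itself, and it leaves the read-out where it was. Acetyl in place of 2-(pyridin-2-yl)ethoxy on an aromatic carbon gives a number 5 percentage points lower from compound 1 to compound 3 (within the scatter), so the three groups now seen on the aniline ring, one of them a far longer chain with a ring of its own, cannot be told apart in this assay. Nothing at hand offers an account of why these groups read alike.

As far as these compounds go, what remains open is whether any group on this carbonyl carbon or aromatic carbon can move the read-out beyond the scatter, for instance a carboxylic acid, an amine or a primary amide in place of the methoxy. Also open, from the compounds shown here alone, is whether a change elsewhere on the shared core, such as a chlorine in place of a trifluoromethyl group, would do more than these changes on the aniline ring have done.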